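A few compounds are considered here, and "the series" means these few. Any claim that something is new, unique, unknown or untested is made for them only; others in the source may bear on it.

Measured compounds in a functional assay on MCF7 cells (Homo sapiens) for antiproliferative activity, read by MTT assay, with a stated time of 72 h; on this read-out higher numbers stand for weaker inhibition and lower numbers for stronger inhibition:

Compound 1 `C/C(=N\Nc1nc(SCc2ccccc2)nc2c1nnn2Cc1ccccc1)c1ccccc1O`: 950 nM
Compound 2 `CCCSc1nc(N/N=C/c2cc(OC)c(OC)c(OC)c2)c2nnn(Cc3ccccc3)c2n1`: a limit of the assay, > 64000 nM
Compound 3 `CCCSc1nc(N/N=C(\C)c2ccccc2O)c2nnn(Cc3ccccc3)c2n1`: 11000 nM

Compound 2 and compound 3 share a propylsulfanyl group; the difference between their cores is not broken down here. Between compound 3 and compound 1 the change is phenyl in place of ethyl on a saturated chain carbon bound to a sulfur, and it gave a 12-fold lower number from compound 3 to compound 1 (1.06 log units; beyond the scatter).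

Compound 4 `COc1cc(/C=N/Nc2nc(SCc3ccccc3)nc3c2nnn3Cc2ccccc2)cc(OC)c1OC` is not yet measured. It arises from compound 2 by phenyl in place of ethyl on a saturated chain carbon bound to a sulfur, the same change at the same place. The starting point is weaker, as compound 2 sits at the limit of > 64000 nM in this assay, at which 1 of the 3 values shown sits; compound 2 thus gives no number to build on, so the step can only be carried over with wide margins. From compound 2 to compound 4 a step of about an at least 3.2-fold lower number from compound 2 to compound 4 (0.50 log units; beyond the scatter) is expected in this assay, resting on a 12-fold lower number from compound 3 to compound 1 (1.06 log units; beyond the scatter). Compound 4 is expected at about 20000 nM, most likely between 5000 nM and 80000 nM.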

Compound 4, half-maximal inhibitory concentration: 13500 nM
Compound 4: the middle estimate sits 1.5-fold (0.17 log units) above what was measured, within the range that was stated.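

In this assay the change from propylsulfanyl to benzylsulfanyl gives an at least 4.7-fold lower number from compound 2 to compound 4 (0.67 log units; beyond the scatter), so the direction of a 12-fold lower number from compound 3 to compound 1 (1.06 log units; beyond the scatter) carries over to the second core. Compound 2 stands at > 64000 nM, which is a limit of the assay, so the size of the step on that core remains unfixed. The data therefore show a shared direction but not a shared size: the same change on two cores in this assay, a 12-fold lower number (1.06 log units; beyond the scatter) from compound 3 to compound 1 and an at least 4.7-fold lower number (0.67 log units; beyond the scatter) from compound 2 to compound 4; the limit leaves it open whether they differ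

Only propyl and benzyl are shown on the sulfur, so the effect of a longer chain, a cyclohexylmethyl group or a benzyl group carrying an amine remains open. For the compounds shown here, with only two pairs, it also remains open whether the step holds on any further core.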